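Swapping a fluorophenyl for a short branched chain

The compounds below may be only part of what the source reports. "The series", "measured", "known", "first", "only" and "open" are said of these compounds alone.

Two compounds share one core and differ only in the group on an aromatic carbon of the fused ring system. Compound 1 `COc1ccc(F)cc1CNCCCNc1ccnc2cc(Cc3cc(C)cc(C)c3)ccc12` carries a 3,5-dimethylbenzyl there, and in an ADME assay on HepG2 cells (Homo sapiens) for cytotoxicity, read by luminescence, CellTiter-Glo and ATP content, with a stated time of 72 h (a lower number here means that less compound is needed, a higher number that more compound is needed for the effect), compound 1 gives 940 nM. Compound 2 `COc1ccc(F)cc1CNCCCNc1ccnc2cc(-c3ccc(F)cc3)ccc12` carries a 4-fluorophenyl instead, and in this assay compound 2 gives 770 nM. Among the measured compounds shown here, the only step measured so far is a 1.2-fold lower number from compound 1 to compound 2 (0.09 log units; within the scatter), so compound 2 sits alongside compound 1 rather than apart from it.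

Compound 3 `CCC(CC)c1ccc2c(NCCCNCc3cc(F)ccc3OC)ccnc2c1` is not yet measured. It changes the same position: pentan-3-yl in place of 4-fluorophenyl on an aromatic carbon. For the measured compounds named here, the one step at this position, from a benzyl to a fluorophenyl, stayed within the scatter, which is the only guide available; the move to pentan-3-yl goes further, to a group without any ring, and no measured step covers such a change. On that basis the expected step is a 1.1-fold higher number from compound 2 to compound 3 (0.04 log units; within the scatter), that is, none beyond the scatter. For compound 3 the estimate in this assay is 850 nM, with a range from 350 nM to 2100 nM.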

Compound 3, half-maximal effective concentration: 7860 nM
Compound 3: the middle estimate sits 9.2-fold (0.97 log units) below what was measured, and the stated range ends below it.
By their numbers in this assay, from the lowest: compounds 2 and 1 (each within the scatter of the next); then compound 3.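

In this assay this position proves sensitive to what sits on it: the change between the two groups carrying an aromatic ring stayed within the scatter, whereas pentan-3-yl in place of 4-fluorophenyl gives a 10-fold higher number from compound 2 to compound 3 (1.01 log units; beyond the scatter) and so calls for clearly more compound to reach the effect. The comparison with the benzyl group points the same way, since pentan-3-yl in place of 3,5-dimethylbenzyl gives an 8.4-fold higher number from compound 1 to compound 3 (0.92 log units; beyond the scatter) and thus sets compound 3 apart from both of the other compounds, which cannot be told apart from each other. Nothing available here explains why this change has so large an effect on the number.

With only three groups at this position, the compounds shown cannot say whether the higher number goes with the loss of any ring, the loss of an aromatic ring in particular, or the branched form of this chain. Going by these compounds, a cyclohexyl group, a saturated ring of carbon, and an unbranched pentyl chain would each separate these readings, and how either would fall remains open.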